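Same atoms, joined differently: estimating compound 4

The compounds below may be only part of what the source reports. "The series", "measured", "known", "first", "only" and "open" are said of these compounds alone.

Values in a functional assay on MOLT-3 cells (Homo sapiens) for cytotoxicity, read by XTT assay, with a stated time of 48 h; a higher number here means a weaker inhibitor, a lower number a stronger inhibitor:
Compound 1 `COc1cccc(/C=C/C(=O)c2cccc(-n3cc(COc4ccc5ccc(=O)oc5c4)nn3)c2)c1OC`: 5160 nM
Compound 2 `COc1ccc(/C=C/C(=O)c2cccc(-n3cc(COc4ccc5ccc(=O)oc5c4)nn3)c2)c(OC)c1OC`: 3890 nM
Compound 3 `COc1ccc(/C=C/C(=O)c2ccc(-n3cc(COc4ccc5ccc(=O)oc5c4)nn3)cc2)c(OC)c1OC`: 22500 nM

Compound 1 lies level with compound 2 within the scatter, and compound 3 gives a higher number than either. Compound 4 `COc1cccc(/C=C/C(=O)c2cccc(-n3cc(COc4cc(=O)oc5ccccc45)nn3)c2)c1OC` has the same atoms as compound 1, joined differently: a group of 11 heavy atoms (9 carbon, 2 oxygen; one six-membered aromatic ring of carbon only, one six-membered aromatic ring with 1 hetero atom) in place of a group of 11 heavy atoms (9 carbon, 2 oxygen; one six-membered aromatic ring of carbon only, one six-membered aromatic ring with 1 hetero atom), on an oxygen on a saturated carbon. Going by the values given here, the only measured step, a 1.3-fold lower number from compound 1 to compound 2 (0.12 log units; within the scatter), puts methoxy in place of hydrogen on an aromatic carbon, which is a different change, so no measurement tests this swap directly. No step beyond the scatter is therefore expected in this assay, and the estimated step is a 1.2-fold higher number from compound 1 to compound 4 (0.07 log units; within the scatter). The high number of compound 3, 22500 nM, keeps the range wide. For compound 4 the expected value is 6000 nM, with an estimated range of 2000 nM to 20000 nM.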

Compound 4, half-maximal inhibitory concentration: 530 nM
Compound 4: middle estimate off by 11-fold (1.05 log units), on the high side, and the stated range ends above it.
By their numbers in this assay, from the lowest: compound 4; then compounds 2 and 1 (each within the scatter of the next); then compound 3.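

In this assay, the way the group on the oxygen is joined matters: with the same atoms in both compounds, the swap gives a 9.7-fold lower number from compound 1 to compound 4 (0.99 log units; beyond the scatter) and so goes beyond the scatter. The earlier step, a 1.3-fold lower number from compound 1 to compound 2 (0.12 log units; within the scatter), added a methoxy and stayed within the scatter. Nothing available explains the difference between the two joined forms. On these data alone, whether the same swap would give a similar step on compound 2 or compound 3 remains open. So does the effect of an amine or a carboxylic acid on the entering group.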